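The source may hold more compounds than are shown below. What is called first, only, known or untested is meant among the compounds shown, and "the series" means these compounds.

Compound 2 `COc1cc2nc(C)nc(-n3nc(-c4ccccn4)nc3N)c2cc1OC` gives, in an assay on MCF7 cells for inhibition of Serine-protein kinase ATM (Homo sapiens), read by immunofluorescence, with a stated time of 1 h (a higher number here means a weaker inhibitor, a lower number a stronger inhibitor), a value of 10100 nM. Compound 1 `COc1cc2nc(Cl)nc(-n3nc(-c4ccccn4)nc3N)c2cc1OC` differs from it by chloro in place of methyl on an aromatic carbon. In this assay compound 1 reaches only the limit of > 40000 nM. That change made an at least 3.9-fold higher number from compound 2 to compound 1 (0.59 log units; beyond the scatter), a step bounded by the limit of > 40000 nM in this assay, at which 2 of the 3 values shown sit. Compound 3 `COc1cc2ncnc(-n3nc(-c4ccc(C)cc4)cc3N)c2cc1OC` carries a different core; the difference between the two cores is not broken down here. In this assay compound 3 also returns only the limit of > 40000 nM. Compound 4 `COc1cc2ncnc(-n3nc(-c4ccc(Cl)cc4)cc3N)c2cc1OC` differs from compound 3 by chloro in place of methyl on an aromatic carbon. The surroundings differ: in compound 1 the chloro sits on a six-membered aromatic ring with 2 nitrogen, between two ring nitrogen atoms, whereas in compound 4 it sits on a six-membered aromatic ring of carbon only, para to a large group, so this is the same kind of change, not the same. With compound 3 already resting at a limit, compound 4 is expected to show a step that the limit leaves unreadable from compound 3 to compound 4. Compound 4 is estimated at 60000 nM in this assay, within 20000 nM to 200000 nM.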

Compound 4, half-maximal inhibitory concentration: > 40000 nM
Compound 4 was reported as a limit; the forecaster's own chance of this, stated with the estimate: 85%; the middle value does not contradict the limit.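

Compound 3 and compound 4 both stop at a limit in this assay, so no step can be read between them: the limit of > 40000 nM in this assay, at which 3 of the 4 values shown sit.

The compounds shown leave open whether the change from 4-methylphenyl to 4-chlorophenyl shifts inhibition at all.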